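A few compounds are considered here, and "the series" means these few. Any claim that something is new, unique, unknown or untested is made for them only; others in the source may bear on it.

Among the measured compounds shown here, in a functional assay on the whole organism with Mus musculus as the target (a lower number here means that less compound is needed, a higher number that more compound is needed for the effect), compound 1 `CN1C(=O)CCC1(O)c1cccc(C(F)(F)F)c1` gives 129 mg/kg as the only actual number so far. For compound 2 `CN(C)C(=O)CCC(=O)c1cccc(C(F)(F)F)c1` the entry > 50 mg/kg is a limit of the assay and not a number. For the measured compounds named here, compound 3 `CC(C)CNC(=O)CCC(=O)c1cccc(C(F)(F)F)c1` differs from compound 2 on a carbonyl carbon, with isobutylamino in place of dimethylamino on a carbonyl carbon as the only change. Going by the values given here, no measured step covers this change, so the expected step that the limit leaves unreadable from compound 2 to compound 3 in this assay is none beyond the scatter, with no direction favoured. For compound 3 the estimate is 60 mg/kg within an expected range of 25 mg/kg to 150 mg/kg for the coming measurement.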

Compound 3, dose for half-maximal effect: > 200 mg/kg
Compound 3: no number, only a limit; the forecaster's own chance of this, stated with the estimate: 35%; middle value at least 3.3-fold (0.52 log units) away from the limit.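

In this assay, among the compounds shown here, compound 2 and compound 3 carry only limits of the assay, and no step between them can be read. From the compounds shown here alone, whether isobutylamino in place of dimethylamino on a carbonyl carbon changes the dose needed remains open.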